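The compounds below may be only part of what the source reports. "The series", "measured", "known", "first", "only" and "open" are said of these compounds alone.

Of the compounds shown here, two have so far been measured in an assay on microsomes from brain for inhibition of Fatty-acid amide hydrolase 1 (Rattus norvegicus), read by fluorescence and HPLC, with a stated time of 60 min; on this read-out higher numbers stand for weaker inhibition and lower numbers for stronger inhibition. Compound 1 `CCCCCCCCc1ccc(OCC(=O)Cn2nnnc2-c2ccc(Cl)cc2)cc1` gives 130 nM. Compound 2 `CCCCCCCCc1ccc(OCC(=O)Cn2nnnc2-c2cccnc2)cc1` gives 190 nM. The step of a 1.5-fold higher number from compound 1 to compound 2 (0.16 log units; within the scatter) exchanges one aromatic ring for another on the shared core. Compound 2 thus holds the highest of the two numbers, with compound 1 nearest to it, and since that gap lies within the scatter, no order between the two can be read from it.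

Compound 3 `CCCCCCCCc1ccc(OCC(=O)Cn2nnnc2-c2ccccn2)cc1` has not yet been measured. It differs from compound 2 in one place: pyridin-2-yl in place of pyridin-3-yl on an aromatic carbon. For the measured compounds named here, only one measured step bears on such a change, and that is the exchange of aromatic rings at the same carbon of the core, which stayed within the scatter. Because a 1.5-fold higher number from compound 1 to compound 2 (0.16 log units; within the scatter) showed so little movement for a ring exchange at that carbon, the expectation is that the further ring exchange in compound 3 also produces no step beyond the scatter, a 1.1-fold higher number from compound 2 to compound 3 (0.02 log units; within the scatter). The estimate for compound 3 in this assay is therefore 200 nM, within a range from 90 nM to 450 nM.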

Compound 3, half-maximal inhibitory concentration: 880 nM
For compound 3 the middle estimate is 4.4-fold (0.64 log units) below the measured one; measured number above the stated range.
By their numbers in this assay, from the lowest: compounds 1 and 2 (each within the scatter of the next); then compound 3.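

In this assay the exchange of pyridin-3-yl for pyridin-2-yl brings a 4.6-fold higher number from compound 2 to compound 3 (0.67 log units; beyond the scatter) even though the two groups hold the same atoms and differ only in how they are joined, so at this aromatic carbon of the shared core the way the pyridine ring is attached matters, and not just the presence of such a ring. The exchange of 4-chlorophenyl for pyridin-2-yl gives a 6.8-fold higher number from compound 1 to compound 3 (0.83 log units; beyond the scatter) in the same direction, while the earlier step of a 1.5-fold higher number from compound 1 to compound 2 (0.16 log units; within the scatter) had suggested that the position accepts different rings with little change. Among these three compounds, then, this position separates pyridin-2-yl from the other two groups, and nothing measured here accounts for that difference.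

On these data alone, it remains open where pyridin-4-yl or an unsubstituted phenyl ring would fall against these three numbers, and so whether pyridin-2-yl is a lone exception among such rings. As far as these compounds go, it is also open whether the same step would appear with a shorter chain in place of the long chain on the shared core.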